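This account rests on a few compounds, and the source may have more. Where it says the series, first, only, none or still open, it means among the compounds named here.

Measured compounds:
compound 1 `C[C@H](Nc1nc(N)nc(N)c1C#N)c1cc2ccc(F)cn2c(=O)c1-c1ccccc1` – 87%
compound 2 `C[C@H](Nc1nc(N)ncc1C#N)c1cc2ccc(F)cn2c(=O)c1-c1ccccc1` – 90%
compound 3 `C[C@H](Nc1ccnc(N)n1)c1cc2ccc(F)cn2c(=O)c1-c1ccccc1` – "not determined" (no result reported)

In an ADME assay on microsomes from liver (Homo sapiens), read by LC-MS, using NADPH, with a stated time of 30 min, tested at 1 uM (on this read-out higher numbers stand for a more stable compound and lower numbers for a less stable compound), compound 1 gives 87% and compound 2 gives 90%. As far as these compounds go, compound 3 has no number in this assay, so its standing on this read-out is unknown. Compound 4 `Cc1nc(N)nc(N[C@@H](C)c2cc3ccc(F)cn3c(=O)c2-c2ccccc2)c1C#N` is not yet measured and differs from compound 3 by 2-amino-5-cyano-6-methylpyrimidin-4-yl in place of 2-aminopyrimidin-4-yl on an amine nitrogen. Among the measured compounds shown here, no measured step matches this change directly. For the measured compounds named here, the only measured step, a number 3 percentage points higher from compound 1 to compound 2 (within the scatter), shows that a change on the same pyrimidine left the read-out within the scatter, and compounds 1 and 2 both carry the nitrile that enters in compound 4. Compound 4 is therefore expected to sit near those two, estimated at 85% with a range from 65% to 98%.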

Compound 4, percent of the compound remaining: 83%
Compound 4: the middle estimate sits 2 percentage points above what was measured; the range from low to high includes it.
By their numbers in this assay, from the lowest: compounds 4, 1 and 2 (each within the scatter of the next).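

At this aromatic carbon of the pyrimidine, this assay now allows hydrogen, amino and methyl to be compared. Methyl in place of hydrogen gives a number 7 percentage points lower from compound 2 to compound 4 (within the scatter) and methyl in place of amino gives a number 4 percentage points lower from compound 1 to compound 4 (within the scatter), so the three groups cannot be told apart on this read-out. Nothing available explains this result.

The step from compound 3 to compound 4 cannot be read. As far as these compounds go, whether a carboxylic acid or a longer chain on this aromatic carbon would also read alike stays open.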